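A few compounds are considered here, and "the series" means these few. Any claim that something is new, unique, unknown or untested is made for them only; others in the source may bear on it.

Of the compounds shown here, three sharing one core have been measured in a functional assay on the whole organism (aorta) with Rattus norvegicus as the target; a lower number here means a smaller maximal response, a higher number a larger maximal response. Compound 1 `C/N=C(/S)C1=CC(C)(C(F)(F)F)Oc2ccc([N+](=O)[O-])cc21` gives 62.5%. Compound 2 `CNC(=O)C1=CC(C)(C(F)(F)F)Oc2ccc([N+](=O)[O-])cc21` gives 61.7%, and the step of a number 0.8 percentage points lower from compound 1 to compound 2 (within the scatter) lies within the scatter. Compound 3 `CC1(CF)C=C(/C(S)=N\CCC#N)c2cc([N+](=O)[O-])ccc2O1` gives 59.6%, the lowest of the three numbers, though within the scatter of both others. Compound 4 `CC1(C(F)(F)F)C=C(/C(S)=N\CCC#N)c2cc([N+](=O)[O-])ccc2O1` has not yet been measured; it differs from compound 3 in one place: trifluoromethyl in place of fluoromethyl on a saturated ring carbon. For the measured compounds named here, no measured step exchanges these two groups, so nothing bears directly on this change; the only measured step, from compound 1 to compound 2, concerns a different position and stayed within the scatter. Compound 4 is therefore expected to stay close to compound 3, with an expected step of a number 1.4 percentage points higher from compound 3 to compound 4 (within the scatter). Compound 4 is estimated at 61%, between 52% and 70%.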

Compound 4, intrinsic activity: the largest response reached, in percent of the reference agonist's: 69.7%
For compound 4 the middle estimate is 8.7 percentage points below the measured one, and the stated range covers the measured number.
By their numbers in this assay, from the lowest: compounds 3, 2, 1 and 4 (each within the scatter of the next, the first and the last beyond it).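

In this assay, for the compounds shown here, trifluoromethyl in place of fluoromethyl on the saturated ring carbon gives a number 10.1 percentage points higher from compound 3 to compound 4 (beyond the scatter), the first step in this set to pass the scatter, so the response does register a change at this position. By contrast, the changes on the side chain, a number 7.2 percentage points higher from compound 1 to compound 4 (within the scatter) and a number 8 percentage points higher from compound 2 to compound 4 (within the scatter), stay within the scatter and establish no difference. Nothing available explains the step at the ring carbon. From the compounds shown here alone, whether difluoromethyl would fall between the two fluorinated groups, and how a plain methyl or an ethyl would compare, remains open.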